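The compounds below may be only part of what the source reports. "The series", "measured", "known", "first", "only" and "open" are said of these compounds alone.

Working notes on the series. Compound 1 `CCCOc1c(-c2cc(OC)c(OC)c(OC)c2)oc2ccccc2c1=O` gives 11800 nM in a functional assay on PC-3 cells (Homo sapiens) for antiproliferative activity, read by WST assay, with a stated time of 3 days; on this read-out higher numbers stand for weaker inhibition and lower numbers for stronger inhibition. Compound 2 `CCCCCOc1c(-c2cc(OC)c(OC)c(OC)c2)oc2ccccc2c1=O` gives 22200 nM in this assay. Compound 3 `CCCCCCCOc1c(-c2cc(OC)c(OC)c(OC)c2)oc2ccccc2c1=O` returns no number in this assay but only a limit, > 50000 nM, and so stands at the limit of > 50000 nM in this assay, at which 1 of the 3 values shown sits. Across the three measured compounds the number rises as the chain on the aromatic oxygen goes from propyl through pentyl to heptyl: a 1.9-fold higher number from compound 1 to compound 2 (0.27 log units; within the scatter), an at least 4.2-fold higher number from compound 1 to compound 3 (0.62 log units; beyond the scatter), and an at least 2.2-fold higher number from compound 2 to compound 3 (0.35 log units; beyond the scatter). Compound 3 therefore stands at the weak end of what is shown, with no finite value of its own.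

Compound 4 `CCCN(CCC)CCCCOc1c(-c2cc(OC)c(OC)c(OC)c2)oc2ccccc2c1=O` is the next step from compound 3: dipropylamino in place of propyl on a saturated chain carbon, four bonds along the chain from an oxygen on an aromatic ring. The measured steps all concern growth of the chain and all run toward higher numbers, and none of them tests a nitrogen in the chain. Since compound 3 gives only a limit, the change for compound 4 can be read only loosely; the step of an at least 1.6-fold lower number from compound 3 to compound 4 (0.22 log units; that floor lies within the scatter) is expected to be small or none beyond the scatter. Compound 4 is estimated at 30000 nM, with a range from 8000 nM to 50000 nM.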

Compound 4, half-maximal inhibitory concentration: 11600 nM
Estimate against measurement, compound 4: 2.6-fold (0.41 log units) above; low and high end bracket the measured number.
By their numbers in this assay, from the lowest: compounds 4, 1 and 2 (each within the scatter of the next). At a limit, above all of these: compound 3.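

Dipropylamino in place of propyl on a saturated chain carbon, four bonds along the chain from an oxygen on an aromatic ring, gives the first step in the series toward lower numbers in this assay: an at least 4.3-fold lower number from compound 3 to compound 4 (0.63 log units; beyond the scatter). A long chain on the aromatic oxygen can therefore carry this nitrogen without the loss seen for heptyl, and compound 4 cannot be ordered against the shorter chains: a 1.9-fold lower number from compound 2 to compound 4 (0.28 log units; within the scatter) and a 1.0-fold lower number from compound 1 to compound 4 (0.01 log units; within the scatter). The first of these comparisons rests on a limit for compound 3, not a number: the limit of > 50000 nM in this assay, at which 1 of the 4 values shown sits.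

Open, going by these compounds, is whether a primary amine, a piperidine or a carboxylic acid at this place would read as dipropylamino does. Also open, on these data alone, is how a shorter or longer chain between the aromatic oxygen and the dipropylamino group would read in this assay.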